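A few compounds are considered here, and "the series" means these few. Any claim that something is new, unique, unknown or untested is made for them only; others in the source may bear on it.

Compound 1 `CNCc1c(OC)cc(Oc2cccc(Nc3ccccc3)c2)cc1OC` and compound 2 `CCN1CCN(Cc2c(OC)cc(Oc3cccc(Nc4ccccc4)c3)cc2OC)CC1` share one core and differ only in the group on a saturated chain carbon bound to an aromatic carbon. In a functional assay on HCT-116 cells (Homo sapiens) for inhibition, read by MTT assay, with a stated time of 72 h (a higher number here means a weaker inhibitor, a lower number a stronger inhibitor), compound 1 reaches only the limit of the assay and gives > 20000 nM. In this assay compound 2 likewise reaches only the limit and gives > 20000 nM. The step that the two limits leave unreadable from compound 1 to compound 2 cannot be read because the limit of > 20000 nM in this assay, at which 2 of the 2 values shown sit, places both of its ends at the same limit. Compound 3 `COc1cc(Oc2cccc(Nc3ccccc3)c2)cc(OC)c1CNC(C)C` has not yet been measured. Compound 3 differs from compound 2 by isopropylamino in place of 4-ethylpiperazin-1-yl on a saturated chain carbon bound to an aromatic carbon. Within the data shown here, no measured step gives a number for an exchange of this kind, and the two values known for this series are both limits, so nothing shows that a small amine in this position lifts the potency into the measurable range. The expectation for compound 3 is therefore that it stays near the same limit, which corresponds to an estimated step that the limit leaves unreadable from compound 2 to compound 3. Compound 3 is estimated at 30000 nM, with a range from 10000 nM to 100000 nM, and the assay is expected most likely to report only a limit again.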

Compound 3, half-maximal inhibitory concentration: > 20000 nM
Compound 3 was reported as a limit (the forecaster's own chance of this, stated with the estimate: 85%); the middle value does not contradict the limit.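

In this assay compound 3 gives > 20000 nM, which is a limit and not a number. Among these compounds, no step among compound 1, compound 2 and compound 3 can be read, because all three end at the same limit: the limit of > 20000 nM in this assay, at which 3 of the 3 values shown sit. The compounds shown leave open how these three amines truly rank, and whether any group at this place gives a measurable value.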